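A few compounds are considered here, and "the series" means these few. Any claim that something is new, unique, unknown or untested is made for them only; others in the source may bear on it.

Compound 1 `CNC(=O)NC1CCN(c2ccc3cc(NC(=O)CCc4ccc(C(F)(F)F)cc4)ccc3n2)C1` carries a methylcarbamoyl group on its pyrrolidine ring. Among the compounds with values here, in an assay on isolated protein for displacement of a labelled ligand from melanin-concentrating hormone receptor 1 (Homo sapiens) (a lower number here means a stronger inhibitor, a higher number a weaker inhibitor), compound 1 gives 6 nM, the only single number among the measured compounds. Compound 2 `O=C(CCc1ccc(C(F)(F)F)cc1)Nc1ccc2nc(N3CCCC3)ccc2c1` shares the same core and in this assay compound 2 gives 3 nM; 3 nM (2 entries), values that sit within the usual scatter of compound 1. Compound 3 `CC(C)C(=O)NC1CCN(c2ccc3cc(NC(=O)CCc4ccc(C(F)(F)F)cc4)ccc3n2)C1` differs from compound 1 by isopropyl in place of methylamino on a carbonyl carbon. Within the data shown here, no measured pair shows this change, so the step from compound 1 to compound 3 is expected to stay modest, at most a slight weakening, as a 1.5-fold higher number from compound 1 to compound 3 (0.18 log units; within the scatter). Compound 3 is expected to give 9 nM, between 3 nM and 27 nM.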

Compound 3, half-maximal inhibitory concentration: 1 nM
For compound 3 the middle estimate is 9.0-fold (0.95 log units) above the measured one; measured number below the stated range.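

In this assay, putting isopropyl in place of methylamino on the carbonyl carbon gives a 6.0-fold lower number from compound 1 to compound 3 (0.78 log units; beyond the scatter), so this position responds to what it carries. The change also removes the hydrogen-bond donor of methylamino, and compound 3 stays a strong inhibitor without it. No measurement shown explains this gain.

Still open, from the compounds shown here alone, is how a longer carbon chain, an amine or a carboxylic acid on this carbonyl carbon would compare with isopropyl. Going by these compounds, it is also open whether a group with a ring there would keep the gain.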